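This account rests on a few compounds, and the source may have more. Where it says the series, first, only, none or still open, it means among the compounds named here.

Of the compounds shown here, three sharing one core have been read in an ADME assay on MT4 cells (Homo sapiens) for cytotoxicity, read by MTT assay, with a stated time of 4 days; a higher number here means that more compound is tolerated, a lower number that less compound is tolerated. In this assay compound 1 `CC(C)N(C)c1nc(Cc2c(F)cccc2F)cc(=O)[nH]1` gives 85000 nM. Compound 3 `Cc1c(Cc2c(F)cccc2F)nc(N(C)C(C)C)[nH]c1=O`, with methyl in place of hydrogen on an aromatic carbon, gives 79000 nM. The measured change is a 1.1-fold lower number from compound 1 to compound 3 (0.03 log units; within the scatter), so compound 3 stands with compound 1, the two values lying within the scatter of each other. Compound 2 `CC1CCN(c2nc(Cc3c(F)cccc3F)cc(=O)[nH]2)CC1` is recorded only as a limit, > 78000 nM, and not as a number.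

Compound 4 `CCN(CC)c1nc(Cc2c(F)cccc2F)c(C)c(=O)[nH]1` keeps the rest of compound 3 but carries diethylamino in place of isopropyl(methyl)amino on an aromatic carbon, between two ring nitrogen atoms (diethylamino in place of isopropyl(methyl)amino on an aromatic carbon). The one measured replacement of isopropyl(methyl)amino is a step that the limit leaves unreadable from compound 1 to compound 2, which offers no size to carry over. Within the data shown here, the methyl change, the only readable measured step, stayed within the scatter, though it lies elsewhere on the core. Nothing measured therefore points to a real shift in either direction in this assay, and the expectation starts from compound 3 at 79000 nM. The estimate is a 1.1-fold lower number from compound 3 to compound 4 (0.02 log units; within the scatter), which is expected to stay within the scatter. Compound 4 is expected at 75000 nM, with an estimated range from 38000 nM to 120000 nM.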

Compound 4, half-maximal cytotoxic concentration: > 81000 nM
Compound 4: only a limit was reported; the forecaster's own chance of this, stated with the estimate: 35%; at least 1.0-fold (0.03 log units) between middle value and limit.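

In this assay compound 4 is recorded only as a limit and not as a number: the limit of > 81000 nM in this assay, at which 1 of the 4 values shown sits.

Set against the measured value on the other side, the exchange of isopropyl(methyl)amino for diethylamino, two groups with the same heavy-atom count and the same atoms, comes out as an at least 1.0-fold higher number from compound 3 to compound 4 (0.01 log units; that floor lies within the scatter), which gives this position between two ring nitrogen atoms its first step with any readable size, even if only a floor, since the earlier replacement there cannot be read. Neither replacement at this position therefore yields a true number to set against its parent, for compound 2 is a limit as well: the limit of > 78000 nM in this assay, at which 1 of the 4 values shown sits.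

The compounds shown leave open how far the true value of compound 4 lies from its limit, and so whether the exchange of these two amino groups has any effect beyond the scatter in this assay. They also leave open whether a different group at this position, such as a morpholin-4-yl ring, a primary amine or a carboxylic acid, would give a value clearly apart from those of compound 1 and compound 3.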